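Swapping trimethylsilyl for a tosylamide on the triazole

The source may report more compounds than this note shows. Statements on the series, on what has been measured and on what is new or still open speak of the compounds shown alone.

Compound 1 `COc1ccccc1-c1cn(C[C@H](O)[C@H]2OC(=O)C(OCc3ccccc3)=C2OCc2ccccc2)nn1`: 50 nM
Compound 2 `O=C1O[C@H]([C@@H](O)Cn2cc(CNS(=O)(=O)c3ccc(F)cc3)nn2)C(OCc2ccccc2)=C1OCc1ccccc1`: 30 nM
Compound 3 `C[Si](C)(C)c1cn(C[C@H](O)[C@H]2OC(=O)C(OCc3ccccc3)=C2OCc2ccccc2)nn1`: 20000 nM

In an ADME assay on HFF cells (Homo sapiens) for cytotoxicity, read by MTT assay, with a stated time of 72 h (a higher number here means a weaker inhibitor, a lower number a stronger inhibitor), compound 3 gives the highest number of the three, the weakest inhibitor here. Compound 4 `Cc1ccc(S(=O)(=O)NCc2cn(C[C@H](O)[C@H]3OC(=O)C(OCc4ccccc4)=C3OCc3ccccc3)nn2)cc1` differs from it in one place: a group of 12 heavy atoms (8 carbon, 1 nitrogen, 2 oxygen, 1 sulfur; one six-membered aromatic ring of carbon only) in place of a group of 4 heavy atoms (3 carbon, 1 silicon; no ring), on an aromatic carbon. Going by the values given here, two measured steps bear on this. The change a 670-fold higher number from compound 2 to compound 3 (2.82 log units; beyond the scatter) and the change a 400-fold higher number from compound 1 to compound 3 (2.60 log units; beyond the scatter) both show that removing an aryl-bearing group from that ring carbon in favour of the silicon group raises the number greatly. Compound 4 restores a group built like that of compound 2, so a large drop in this assay is expected, roughly a 500-fold lower number from compound 3 to compound 4 (2.70 log units; beyond the scatter). The value for compound 4 is therefore estimated at 40 nM, within 15 nM to 150 nM.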

Compound 4, half-maximal inhibitory concentration: 50 nM
Estimate against measurement, compound 4: 1.3-fold (0.10 log units) below, and the stated range covers the measured number.
By their numbers in this assay, from the lowest: compounds 2, 1 and 4 (each within the scatter of the next); then compound 3.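

In this assay the silicon group stands alone at this ring carbon: replacing it gives a 400-fold lower number from compound 3 to compound 4 (2.60 log units; beyond the scatter) while methyl in place of fluoro gives only a 1.7-fold higher number from compound 2 to compound 4 (0.22 log units; within the scatter) and so makes no real difference. Putting (((4-methylphenyl)sulfonyl)amino)methyl in place of 2-methoxyphenyl gives no change at the digits printed from compound 1 to compound 4 (within the scatter) so these two unlike groups, each carrying an aromatic ring, sit at one level. No evidence is available on why the silicon group differs.

On these data alone, whether an amine, a carboxylic acid or a plain methyl at this ring carbon would behave like the silicon group or like the ring-bearing groups stays open.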